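From bromo to cyano on the aromatic ring

A few compounds are considered here, and "the series" means these few. Any claim that something is new, unique, unknown or untested is made for them only; others in the source may bear on it.

In a functional assay on MCF7 cells (Homo sapiens) for cytotoxicity, read by MTT assay, with a stated time of 48 h (on this read-out lower numbers stand for stronger inhibition and higher numbers for weaker inhibition), compound 1 `OC[C@@H]1C[C@H](CO)[C@@H]2C(c3ccc(Cl)cc3)=NO[C@H]12` gives 14.7 ug/mL as a true number. Compound 2 `Cc1ccc(C2=NO[C@@H]3[C@H](CO)C[C@H](CO)[C@H]23)cc1` reads > 50 ug/mL which is a limit. Compound 3 `OC[C@@H]1C[C@H](CO)[C@@H]2C(c3ccc(Br)cc3)=NO[C@H]12` reads > 50 ug/mL which is also a limit, so it has no exact number. Within the data shown here, the picture is thus shaped by the limit of > 50 ug/mL in this assay, at which 2 of the 3 values shown sit, and only one compound gives a true number. Compound 4 `N#Cc1ccc(C2=NO[C@@H]3[C@H](CO)C[C@H](CO)[C@H]23)cc1` carries cyano in place of bromo on an aromatic carbon para to a large group. Two measured swaps at that place bear on it: an at least 3.4-fold higher number from compound 1 to compound 2 (0.53 log units; beyond the scatter) and an at least 3.4-fold higher number from compound 1 to compound 3 (0.53 log units; beyond the scatter) with both moving towards weaker inhibition. Neither starts from compound 3, so no step beyond the scatter is expected in this assay although a lower number remains possible. The estimated change is an at least 1.1-fold lower number from compound 3 to compound 4 (0.04 log units; that floor lies within the scatter) and it remains a rough expectation. For compound 4 the estimated value is 45 ug/mL with an expected range of 15 ug/mL to 100 ug/mL until it is measured.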

Compound 4, half-maximal inhibitory concentration: > 50 ug/mL
Compound 4 ended at the assay's limit (the forecaster's own chance of this, stated with the estimate: 55%); middle value at least 1.1-fold (0.04 log units) from the limit.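

In this assay, among these compounds, cyano in place of chloro gives an at least 3.4-fold higher number from compound 1 to compound 4 (0.53 log units; beyond the scatter), so a third group at this place on the aromatic ring falls short of chloro, which remains the only group here with a true number. The limit now hides any ranking among the other groups, and the steps between compound 2, compound 3 and compound 4 cannot be read: the limit of > 50 ug/mL in this assay, at which 3 of the 4 values shown sit.

Going by these compounds, it remains open whether an amine, a fluoro group or a carboxylic acid at this place would match chloro. It is also unclear whether any group there could give a lower number than compound 1.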